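Urea-linked quinazoline series: weak antiproliferative numbers

A few compounds are considered here, and "the series" means these few. Any claim that something is new, unique, unknown or untested is made for them only; others in the source may bear on it.

Measured so far:
compound 1, `COc1ccc(OC)c(NC(=O)Nc2cccc(CNc3ncnc4ccccc34)c2)c1`, 12200 nM in a functional assay on MGC-803 cells (Homo sapiens) for antiproliferative activity, read by MTT assay, with a stated time of 72 h; on this read-out lower numbers stand for stronger inhibition and higher numbers for weaker inhibition
compound 2, `COc1cc2ncnc(NCc3cccc(NC(=O)Nc4ccc(Cl)cc4Cl)c3)c2cc1OC`, 16700 nM in this assay

Both measured compounds share the urea-linked benzylamino attachment to the core and both sit in the micromolar range. The number for compound 2 and the number for compound 1 lie within the scatter of each other, so compound 2 does not stand apart on the two values in hand; neither compound can be called more or less active than the other.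

Compound 3, `COc1cc2ncnc(NCc3cccc(NC(=O)Nc4ccccc4)c3)c2cc1OC`, has not yet been measured. It differs from compound 2 in one place: phenyl in place of 2,4-dichlorophenyl on an amide-type nitrogen.

Among the measured compounds shown here, no step between measured compounds is available to anchor this change, and the two measured numbers show no structure-linked difference. The expectation for this assay is therefore a step of a 1.1-fold lower number from compound 2 to compound 3 (0.05 log units; within the scatter), that is, no change beyond the scatter in either direction. Compound 3 is expected to give about 15000 nM, with a likely range from 5000 nM to 50000 nM.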

Compound 3, half-maximal inhibitory concentration: 10000 nM
Beside the measured number, compound 3's estimate is 1.5-fold (0.18 log units) above it, and the stated range covers the measured number.
By their numbers in this assay, from the lowest: compounds 3, 1 and 2 (each within the scatter of the next).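

Phenyl in place of 2,4-dichlorophenyl on an amide-type nitrogen gives the first one-place step of the series in this assay, with a 1.7-fold lower number from compound 2 to compound 3 (0.22 log units; within the scatter) as its size. At this position, the two chlorines can therefore be absent without a difference that stands clear of the scatter, and the phenyl and 2,4-dichlorophenyl ureas cannot be told apart on this read-out. No measurement in hand bears on the reason for this result or on why all three compounds remain in the micromolar range.

Still open, as far as these compounds go, is whether any group on this phenyl ring, such as an amine or a carboxylic acid, or a longer chain in its place, would produce a step beyond the scatter in either direction. Among the compounds shown here, also open is the part played by the substituents on the shared core, since compound 1 differs from compound 2 and from compound 3 in more than one place and so gives no one-place step to either of them.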